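Series notes: the step from compound 2 to compound 3

The source may hold more compounds than are shown below. What is called first, only, known or untested is meant among the compounds shown, and "the series" means these compounds.

Two compounds of this series carry numbers in a functional assay for inhibition of sodium/hydrogen exchanger (Oryctolagus cuniculus); on this read-out lower numbers stand for stronger inhibition and higher numbers for weaker inhibition. Compound 1 `CCc1cc(Br)c(S(C)(=O)=O)cc1C(=O)N=C(N)N` gives 41 nM in this assay. Compound 2 `Cc1cc(C)c(S(C)(=O)=O)cc1C(=O)N=C(N)N` gives 11 nM in this assay, the lowest of the two numbers; compound 1 stands at a higher number, and the gap between the two lies beyond the usual scatter. Compound 1 and compound 2 differ in more than one place, so that gap tells nothing about either change alone.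

Compound 3 `Cc1cc(C2CCCCC2)c(S(C)(=O)=O)cc1C(=O)N=C(N)N` is not yet measured. It differs from compound 2 by cyclohexyl in place of methyl on an aromatic carbon. Within the data shown here, no measured pair differs at this position alone, so no step can be read from the data for it. The entering group is much larger than the one it replaces, and the number is expected to move higher by a moderate step. Compound 3 is expected to give 40 nM, with a range from 10 nM to 200 nM. The estimated step from compound 2 to compound 3 is a 3.6-fold higher number from compound 2 to compound 3 (0.56 log units; beyond the scatter), beyond the scatter.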

Compound 3, half-maximal inhibitory concentration: 22 nM
Beside the measured number, compound 3's estimate is 1.8-fold (0.26 log units) above it; low and high end bracket the measured number.
By their numbers in this assay, from the lowest: compounds 2, 3 and 1 (each within the scatter of the next, the first and the last beyond it).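

In this assay, among these compounds, cyclohexyl in place of methyl gives a 2.0-fold higher number from compound 2 to compound 3 (0.30 log units; within the scatter) and so provides the first reading of this position on its own, which compound 1 could not give. The aromatic carbon ortho to a methylsulfonyl group therefore accepts a non-aromatic ring of 6 heavy atoms in place of a single carbon, with no difference beyond the usual scatter in this read-out. No measured information available here bears on the reason for this result.

As far as these compounds go, only these two groups have been compared at this position, so how an amine, a carboxylic acid or a longer alkyl chain would read there remains open. Compound 1 differs from the other compounds in more than one place, so the steps to it cannot be read.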